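Benzamide ring changes on a shared core: compound 4

A few compounds are considered here, and "the series" means these few. Any claim that something is new, unique, unknown or untested is made for them only; others in the source may bear on it.

Going by the values given here, compound 3 `O=C(Nc1ccc(Cl)c(-c2nnc3c(Cl)cccn23)c1)c1ccc(Cl)cc1Cl` is the only member with a number in a functional assay on MCF7 cells (Homo sapiens) for antiproliferative activity, read by MTT assay, with a stated time of 72 h (a higher number here means a weaker inhibitor, a lower number a stronger inhibitor), where compound 3 gives 78200 nM. Compound 1 `O=C(Nc1ccc(Cl)c(-c2nnc3c(Cl)cccn23)c1)c1ccc(F)cc1Cl` stops at the limit > 100000 nM in this assay. Compound 2 `Cc1cc(Cl)ccc1C(=O)Nc1ccc(Cl)c(-c2nnc3c(Cl)cccn23)c1` likewise stops at the limit > 100000 nM. The steps toward compound 3 are an at least 1.2-fold lower number from compound 1 to compound 3 (0.10 log units; that floor lies within the scatter) and an at least 1.2-fold lower number from compound 2 to compound 3 (0.10 log units; that floor lies within the scatter), both only floors within the scatter, and the limit of > 100000 nM in this assay, at which 2 of the 3 values shown sit, bounds two of the three values. Compound 4 `O=C(Nc1ccc(Cl)c(-c2nnc3c(Cl)cccn23)c1)c1c(F)cccc1Cl` carries 2-chloro-6-fluorophenyl in place of 2,4-dichlorophenyl on a carbonyl carbon, the reverse in kind of the fluoro-to-chloro step. No change beyond the scatter is expected in this assay, and a return to the limit is quite possible. Compound 4 is therefore expected near 100000 nM (range 40000 nM to 300000 nM). The step of a 1.3-fold higher number from compound 3 to compound 4 (0.11 log units; within the scatter) is expected to stay within the scatter.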

Compound 4, half-maximal inhibitory concentration: > 100000 nM
Compound 4 was reported as a limit (the forecaster's own chance of this, stated with the estimate: 60%); the middle value lies on the limit itself.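

The 2-chloro-6-fluorophenyl group in place of 2,4-dichlorophenyl on the carbonyl carbon gives, in this assay, an at least 1.2-fold higher number from compound 3 to compound 4 (0.10 log units; that floor lies within the scatter). The value of compound 4 is a limit of the assay, not a number. The steps from compound 1 and compound 2 to compound 4 cannot be read, and this third halogen-bearing or methyl-bearing ring without a number shows that the single number in the series remains that of compound 3: the limit of > 100000 nM in this assay, at which 3 of the 4 values shown sit.

Open, on these data alone, is whether an amine, a carboxylic acid or a morpholine on this ring would move the number beyond the scatter. Also open, as far as these compounds go, is whether any change to the shared core would do so.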